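This account rests on a few compounds, and the source may have more. Where it says the series, first, only, none or still open, it means among the compounds named here.

Among the compounds with values here, compound 1 `CCCn1c(=O)[nH]c2nc(-c3ccc(S(=O)(=O)N4CCN(C)CC4)cc3)[nH]c2c1=O` is the one member of this set that gives an actual number in an assay on CHO cells for displacement of a labelled ligand from adenosine receptor A1 (Homo sapiens), read by scintillation counting, with a stated time of 90 min, in the presence of a further agent that is not named here (a lower number here means a stronger inhibitor, a higher number a weaker inhibitor), at 334 nM. Compound 2 `CCCn1c(=O)[nH]c2nc(-c3ccc(S(=O)(=O)N4CCN(c5ccc(F)cc5)CC4)cc3)[nH]c2c1=O` reaches only the limit of the assay, > 1000 nM. Compound 3 `CCCn1c(=O)[nH]c2nc(-c3ccc(S(=O)(=O)N4CCN(c5ccccc5F)CC4)cc3)[nH]c2c1=O` likewise stops at the limit, > 1000 nM. Both aryl replacements on that ring nitrogen were at least modest losses: an at least 2.9-fold higher number from compound 1 to compound 2 (0.47 log units; beyond the scatter), and an at least 2.9-fold higher number from compound 1 to compound 3 (0.47 log units; beyond the scatter). Compound 4 `CCCn1c(=O)[nH]c2nc(-c3ccc(S(=O)(=O)N4CCN(c5ccc(C)cc5)CC4)cc3)[nH]c2c1=O` carries the change (4-methylphenyl in place of methyl on an amine nitrogen in a ring). The two earlier steps bear directly on it, since 4-methylphenyl is again an aromatic group entering at the same place, so a loss of similar or greater size is expected, with a fair chance that the assay once more records only the limit (the limit of > 1000 nM in this assay, at which 2 of the 3 values shown sit). Compound 4 is therefore expected at 1800 nM (range 600 nM to 6000 nM), which would be a step of a 5.4-fold higher number from compound 1 to compound 4 (0.73 log units; beyond the scatter).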

Compound 4, inhibition constant: > 1000 nM
Compound 4 was reported as a limit (the forecaster's own chance of this, stated with the estimate: 70%); the middle value lies beyond the limit too.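

In this assay, placing 4-methylphenyl on the amine nitrogen in the ring gives an at least 2.9-fold higher number from compound 1 to compound 4 (0.47 log units; beyond the scatter), so the loss seen with the two fluorophenyl groups also appears with an aromatic ring carrying methyl instead of fluoro. Compound 2, compound 3 and compound 4 now all lose against compound 1, and no compound shown goes against this. The steps among those three cannot be read, because each ends at a limit: the limit of > 1000 nM in this assay, at which 3 of the 4 values shown sit.

As far as these compounds go, whether hydrogen, an ethyl chain or a benzyl group on that nitrogen would match compound 1 remains open, as does any ranking among the aromatic groups.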